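The compounds below may be only part of what the source reports. "The series", "measured", "known", "first", "only" and "open" are said of these compounds alone.

Measured so far:
compound 1 `CCOC(=O)C1=Cc2ccccc2OC1(OCc1cc(-c2ccc(OC)cc2)no1)C(F)(F)F`: > 150000 nM
compound 2 `CCOC(=O)C1=Cc2ccccc2OC1(OCc1cn(CC(=O)Nc2ccccc2Br)nn1)C(F)(F)F`: > 150000 nM
compound 3 `CCOC(=O)C1=Cc2ccccc2OC1(OCc1cn(CC(=O)Nc2ccc(C)cc2)nn1)C(F)(F)F`: 54300 nM

In a functional assay on A549 cells (Homo sapiens) for inhibition, read by MTT assay, with a stated time of 24 h (on this read-out higher numbers stand for weaker inhibition and lower numbers for stronger inhibition), compound 1 gives > 150000 nM, which is a limit of the assay and not a number. Compound 2 also sits at a limit, > 150000 nM. Compound 3 gives 54300 nM. Among the measured compounds shown here, the only measured step, an at least 2.7-fold lower number from compound 2 to compound 3 (0.44 log units; beyond the scatter), changes the group on the amide-type nitrogen and says nothing about the change that leads to compound 4 `CCOC(=O)C1=Cc2ccccc2OC1(OCc1cc(-c2ccc([N+](=O)[O-])cc2)no1)C(F)(F)F`, which is nitro in place of methoxy on an aromatic carbon. For the measured compounds named here, two of the three numbers sit at the limit (the limit of > 150000 nM in this assay, at which 2 of the 3 values shown sit), and no measured step touches the part of the core that changes here, so compound 1 gives no direction. Compound 4 is expected to remain near the limit, with an estimated step that the limit leaves unreadable from compound 1 to compound 4; the estimate for compound 4 is 200000 nM, ranging from 60000 nM to 700000 nM.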

Compound 4, half-maximal inhibitory concentration: > 150000 nM
Compound 4 was reported as a limit; the forecaster's own chance of this, stated with the estimate: 70%; the middle value lies beyond the limit too.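

No step can be read from compound 1 to compound 4, because both values are limits of the assay and not numbers: the limit of > 150000 nM in this assay, at which 3 of the 4 values shown sit. On these data alone, whether nitro in place of methoxy shifts inhibition in either direction remains open.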